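Ester Chain to Benzyl Ester: Compound 3 to Compound 4

The source may hold more compounds than are shown below. What is called first, only, known or untested is meant among the compounds shown, and "the series" means these compounds.

Measured compounds:
- compound 1, `CC1=C(C(=O)OCc2ccccc2)C(c2ccco2)NC(=S)N1`, 4%
- compound 2, `CCCOC(=O)C1=C(C)NC(=S)NC1c1ccoc1`, 3%
- compound 3, `CC1=C(C(=O)OCC(C)C)C(c2ccoc2)NC(=S)N1`, 1%

All three share one core and differ in the ester group and in where the furan ring is joined. In an assay on membranes from HeLa cells for displacement of a labelled ligand from adenosine receptor A3 (Homo sapiens), read by scintillation counting, with a stated time of 180 min, tested at 1 uM (on this read-out higher numbers stand for more inhibition at the one concentration tested (going by the name of the read-out) and lower numbers for less inhibition), compound 3 gives the lowest of the three numbers, though the nearest, compound 2, and the furthest, compound 1, both lie within the scatter of it, so no order among them can be read. Going by the values given here, the one counted step, a number 2 percentage points lower from compound 2 to compound 3 (within the scatter), changes the ester chain alone and moves nothing beyond the scatter.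

Compound 4, `CC1=C(C(=O)OCc2ccccc2)C(c2ccoc2)NC(=S)N1`, differs from compound 3 by phenyl in place of isopropyl on a saturated chain carbon bound to an oxygen next to a carbonyl group. Compound 1 carries the same benzyl ester but with the furan joined at a different point, so only its value and that of compound 3 can be set side by side, and they sit within the scatter of each other. With every shown number low and flat, the expected step of a number 2 percentage points higher from compound 3 to compound 4 (within the scatter) is none beyond the scatter. Compound 4 is therefore estimated at 3%, expected between 0% and 9%.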

Compound 4, a percentage reported as inhibition, at one concentration (the size of the read-out at that concentration, not a potency): 20%
Estimate against measurement, compound 4: 17 percentage points below, and the stated range ends below it.
By their numbers in this assay, from the lowest: compounds 3, 2 and 1 (each within the scatter of the next); then compound 4.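

Phenyl in place of isopropyl on the saturated chain carbon bound to an oxygen next to a carbonyl group gives a number 19 percentage points higher from compound 3 to compound 4 (beyond the scatter) in this assay, and phenyl in place of ethyl at that same place gives a number 17 percentage points higher from compound 2 to compound 4 (beyond the scatter), so this ester position can change the read-out, which the earlier step within the scatter did not show. Phenyl alone does not account for the rise, as furan-3-yl in place of furan-2-yl on the saturated ring carbon gives a number 16 percentage points higher from compound 1 to compound 4 (beyond the scatter), and the higher number appears here only where the benzyl ester and furan-3-yl occur together. Nothing available explains this rise.

As far as these compounds go, whether a longer chain ending in phenyl, or a phenyl ring carrying an amine, would raise the number further stays open. A reading at one concentration also leaves the potency of compound 4 unknown.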